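Oxazolidinone series: cytotoxicity of the side-chain variants

This account rests on a few compounds, and the source may have more. Where it says the series, first, only, none or still open, it means among the compounds named here.

Values in an ADME assay on L02 cells (Homo sapiens) for cytotoxicity, read by MTT assay, with a stated time of 48 h; a higher number here means a weaker inhibitor, a lower number a stronger inhibitor:
compound 1 `CN1CCN(C[C@H]2CN(c3ccc(-n4cc(-c5ccccn5)cn4)c(F)c3)C(=O)O2)CC1` — 70 ug/mL
compound 2 `O=C1CNC(=O)N1C[C@H]1CN(c2ccc(-n3cc(-c4ccccn4)cn3)c(F)c2)C(=O)O1` — > 400 ug/mL
compound 3 `COC[C@H]1CN(c2ccc(-n3cc(-c4ccccn4)cn3)c(F)c2)C(=O)O1` — > 400 ug/mL

Compound 3 stands at the limit of this assay (the limit of > 400 ug/mL in this assay, at which 2 of the 3 values shown sit); its value is a limit, not a number. The value of compound 2 is likewise a limit. Among the measured compounds shown here, compound 1 is the only member with a number. From compound 1 the steps to the two others read an at least 5.7-fold higher number from compound 1 to compound 2 (0.75 log units; beyond the scatter) and an at least 5.7-fold higher number from compound 1 to compound 3 (0.75 log units; beyond the scatter), both beyond the scatter. Between the two limit compounds the step that the two limits leave unreadable from compound 2 to compound 3 cannot be read.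

Compound 4 `O=CNC[C@H]1CN(c2ccc(-n3cc(-c4ccccn4)cn3)c(F)c2)C(=O)O1` is not yet measured. Its change from compound 3 is formylamino in place of methoxy on a saturated chain carbon bound to a saturated ring carbon, a change that does not touch the 4-methylpiperazin-1-yl group whose removal gave both readable steps. For the measured compounds named here, no measured step compares methoxy with formylamino; the steps from compound 1 only show that the two side chains without that group both sit at the limit. No step beyond the scatter in this assay is therefore expected for compound 4, and a limit is the likely outcome.

Compound 4 is estimated at 450 ug/mL, range 200 ug/mL to 1000 ug/mL, which means an expected step that the limit leaves unreadable from compound 3 to compound 4.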

Compound 4, half-maximal inhibitory concentration: > 400 ug/mL
Compound 4 gave a limit, no number; the forecaster's own chance of this, stated with the estimate: 75%; the middle value is on the limit's open side.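

The change from methoxy to formylamino on a saturated chain carbon bound to a saturated ring carbon adds a hydrogen-bond donor and a double bond outside aromatic rings, yet compound 4 still gives only a limit in this assay, the third side chain without the 4-methylpiperazin-1-yl group to do so: the limit of > 400 ug/mL in this assay, at which 3 of the 4 values shown sit. Formylamino in place of 4-methylpiperazin-1-yl gives an at least 5.7-fold higher number from compound 1 to compound 4 (0.75 log units; beyond the scatter), so compound 1 remains the only member with a number. The steps among compound 2, compound 3 and compound 4 cannot be read, as all of them end in limits.

As far as these compounds go, how far these three side chains lie past the limit stays open, and no order among them can be given. From the compounds shown here alone, whether a primary amine or a carboxylic acid at this place would return a number is also open.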